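A few compounds are considered here, and "the series" means these few. Any claim that something is new, unique, unknown or untested is made for them only; others in the source may bear on it.

Three compounds share the same core and differ only in the group attached to the sulfonyl sulfur. Compound 1 `CCS(=O)(=O)c1nnc(COc2cc(C)c3c(C)cc(=O)oc3c2)o1` carries an ethyl group there. In a functional assay on MDA-MB-231 cells (Homo sapiens) for antiproliferative activity, read by MTT assay, with a stated time of 24 h (on this read-out higher numbers stand for weaker inhibition and lower numbers for stronger inhibition), compound 1 gives only a limit of > 100000 nM. Compound 2 `CCCCCCS(=O)(=O)c1nnc(COc2cc(C)c3c(C)cc(=O)oc3c2)o1` carries a hexyl group. In this assay compound 2 likewise gives only a limit, > 100000 nM. Because both values sit at the limit of > 100000 nM in this assay, at which 2 of the 3 values shown sit, the step that the two limits leave unreadable from compound 1 to compound 2 cannot be read. For the measured compounds named here, compound 3 `Cc1cc(OCc2nnc(S(=O)(=O)Cc3ccccc3)o2)cc2oc(=O)cc(C)c12` carries a benzyl group, and in this assay compound 3 gives 7070 nM, the only number among the three. Going by the values given here, the steps of an at least 14-fold lower number from compound 1 to compound 3 (1.15 log units; beyond the scatter) and an at least 14-fold lower number from compound 2 to compound 3 (1.15 log units; beyond the scatter) show that the benzyl group is the one change that brings the read-out into the measurable range. Compound 4 `Cc1cc(OCc2nnc(S(=O)(=O)Cc3cccc(F)c3)o2)cc2oc(=O)cc(C)c12` is the next step from compound 3: fluoro in place of hydrogen on an aromatic carbon. Among the compounds with values here, none of the measured steps touches a substituent on this ring; they all compare the benzyl group with saturated chains, so they give no size for this change. The expected step of a 1.0-fold lower number from compound 3 to compound 4 (0.00 log units; within the scatter) is therefore none beyond the scatter. Compound 4 is estimated at 7000 nM, in a range from 2500 nM to 20000 nM.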

Compound 4, half-maximal inhibitory concentration: 21300 nM
Beside the measured number, compound 4's estimate is 3.0-fold (0.48 log units) below it, and the stated range ends below it.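

For the compounds shown here, the ring of the benzyl group had no measured comparison among the earlier compounds, and this result shows that a change there can be read: with a fluoro group on an aromatic carbon, meta to a large group, this assay gives a 3.0-fold higher number from compound 3 to compound 4 (0.48 log units; beyond the scatter), so this single added atom moves the read-out towards weaker inhibition. The 3-fluorobenzyl group still keeps the read-out in the measurable range, as shown by an at least 4.6-fold lower number from compound 2 to compound 4 (0.67 log units; beyond the scatter) and by an at least 4.6-fold lower number from compound 1 to compound 4 (0.67 log units; beyond the scatter), so the advantage of the benzyl group over the ethyl and hexyl chains survives the change. These two steps give only a minimum size, because compound 1 and compound 2 each supply a limit rather than a number: the limit of > 100000 nM in this assay, at which 2 of the 4 values shown sit.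

A single substituent at a single place cannot show whether the loss belongs to fluoro itself or to where it sits, so the same fluoro group on another carbon of the ring remains an open question. As far as these compounds go, it is also open whether a chloro, methoxy or amino group on this ring would shift the read-out in the same direction, or in the opposite one.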